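The compounds below may be only part of what the source reports. "The series", "measured", "known", "first", "only" and "open" are said of these compounds alone.

Measured compounds:
- compound 1, `O=C1C=C(Nc2ccc(I)cc2)C(=O)c2c1nc1n2[C@H]2OC[C@@H](O)[C@H]2OC1`, 1400 nM
- compound 2, `O=C1C(NC2CC2)=CC(=O)c2c1nc1n2[C@H]2OC[C@@H](O)[C@H]2OC1`, > 4000 nM

For the measured compounds named here, compound 1 carries the only numerical reading in a functional assay on MGC-803 cells (Homo sapiens) for inhibition, read by sulforhodamine B assay; on this read-out lower numbers stand for stronger inhibition and higher numbers for weaker inhibition; in that assay compound 1 gives 1400 nM. For compound 2 the same assay reports only a limit, > 4000 nM, which is the limit of > 4000 nM in this assay, at which 1 of the 2 values shown sits, rather than a number. No step between two measured compounds is shown, so the two values of compound 1 and compound 2 say nothing about a size of change on their own.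

Compound 3, `COc1cccc(NC2=CC(=O)c3nc4n(c3C2=O)[C@H]2OC[C@@H](O)[C@H]2OC4)c1`, is not yet measured. Compared with compound 1 it differs in one place: 3-methoxyphenyl in place of 4-iodophenyl on an amine nitrogen. The step from compound 1 to compound 3 is expected to be small, most likely within the usual scatter, with a slight lean toward weaker inhibition; the expected step is a 1.4-fold higher number from compound 1 to compound 3 (0.15 log units; within the scatter). Compound 3 is therefore estimated at 2000 nM, with the likely range running from 700 nM to 6000 nM.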

Compound 3, half-maximal inhibitory concentration: 1780 nM
Estimate against measurement, compound 3: 1.1-fold (0.05 log units) above; low and high end bracket the measured number.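

On this assay, 3-methoxyphenyl in place of 4-iodophenyl on the amine nitrogen gives a 1.3-fold higher number from compound 1 to compound 3 (0.10 log units; within the scatter). For the compounds shown here, this is the first comparison that differs in one place, and it shows that this position takes both aryl groups with readings that stay within the scatter of each other, even though one carries iodine and the other an oxygen-bearing methoxy group. No available measurement bears on why these two groups read alike.

The change moves the ring substituent and alters its identity in a single step, leaving the two effects unseparated, and an unsubstituted phenyl, a 4-methoxyphenyl or a phenyl bearing a carboxylic acid would be needed to pull them apart. Compound 2 gives only a limit, > 4000 nM, and differs from compound 1 in more than one place, leaving open how an alkyl amine would read at this position.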